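The source may report more compounds than this note shows. Statements on the series, on what has been measured and on what is new or still open speak of the compounds shown alone.

In an ADME assay on cells (Hepatocyte, Rattus norvegicus) for pharmacokinetics (on this read-out lower numbers stand for slow clearance and higher numbers for fast clearance), compound 2 `O=S(=O)(c1ccc(F)cc1)c1cc(F)c(O)c2ncccc12` gives 15 uL/min, while compound 3 `Cc1ccc(S(=O)(=O)c2cc(F)c(O)c3ncccc23)cc1` gives 36 uL/min, the higher of the two numbers, the pair being separated by a 2.4-fold higher number from compound 2 to compound 3 (0.38 log units; beyond the scatter). In this assay compound 1 `O=S(=O)(c1ccc(O)c2ncccc12)C1CCCC1` gives "not determined" (no result reported). Compound 4 `O=S(=O)(c1cc(F)c(O)c2ncccc12)C1CCCC1` differs from compound 3 by cyclopentyl in place of 4-methylphenyl on a sulfonyl sulfur. Within the data shown here, the only measured step, a 2.4-fold higher number from compound 2 to compound 3 (0.38 log units; beyond the scatter), concerns a substituent on an aromatic carbon and not the group on the sulfonyl sulfur, so it bears on this change only loosely, and compound 1, the sole other entry carrying a cyclopentyl there, offers no number. The direction of the step is therefore open. Compound 4 is expected to give about 25 uL/min, within 10 uL/min to 60 uL/min, an estimated step of a 1.4-fold lower number from compound 3 to compound 4 (0.16 log units; within the scatter) that may well remain within the scatter.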

Compound 4, intrinsic clearance in a liver preparation (reported as CLH), per the amount of preparation that the assay uses: 19 uL/min
Compound 4: the middle estimate sits 1.3-fold (0.12 log units) above what was measured, within the range that was stated.
By their numbers in this assay, from the lowest: compounds 2, 4 and 3 (each within the scatter of the next, the first and the last beyond it).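

Replacing 4-methylphenyl with cyclopentyl on the sulfonyl sulfur gives a 1.9-fold lower number from compound 3 to compound 4 (0.28 log units; within the scatter) in this assay, and replacing 4-fluorophenyl with it gives a 1.3-fold higher number from compound 2 to compound 4 (0.10 log units; within the scatter). Among these compounds, this position therefore takes a non-aromatic five-membered carbon ring in place of either aromatic ring without a step beyond the scatter, the first such reading for this change. No measured evidence accounts for this result. Still open, going by these compounds, is how an amine or a longer chain on the sulfonyl sulfur would read in this assay. Compound 1 gives "not determined" (no result reported), leaving the fluoro on the core of compound 4 untested alongside cyclopentyl.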